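Removing a methyl from the linker of compound 2

A few compounds are considered here, and "the series" means these few. Any claim that something is new, unique, unknown or untested is made for them only; others in the source may bear on it.

Measured so far:
- compound 1, `Cc1cc(C)cc(S(=O)(=O)c2c(C(=O)NC(C)C(=O)NCCn3c(C)cnc3[N+](=O)[O-])[nH]c3ccc(Cl)cc23)c1`: 16000 nM
- compound 2, `Cc1cc(C)cc(S(=O)(=O)c2c(C(=O)NC(C)C(=O)NCc3ccco3)[nH]c3ccc(Cl)cc23)c1`: 24200 nM
- compound 3, `COc1cccc(F)c1CNC(=O)c1[nH]c2ccc(Cl)cc2c1S(=O)(=O)c1cc(C)cc(C)c1`: > 49900 nM

In an ADME assay on MT4 cells (Homo sapiens) for cytotoxicity, read by MTT assay (a higher number here means that more compound is tolerated, a lower number that less compound is tolerated), compound 2 gives 24200 nM. Of the two plain numbers this is the higher one, though the step between these two compounds is a 1.5-fold higher number from compound 1 to compound 2 (0.18 log units; within the scatter), which lies within the scatter. For compound 3 only a limit of the assay is known, > 49900 nM, not a number; it is recorded as the limit of > 49900 nM in this assay, at which 1 of the 3 values shown sits.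

Compound 4, `Cc1cc(C)cc(S(=O)(=O)c2c(C(=O)NCC(=O)NCc3ccco3)[nH]c3ccc(Cl)cc23)c1`, has not yet been measured. It differs from compound 2 by hydrogen in place of methyl on a saturated chain carbon bound to an amide-type nitrogen and a carbonyl carbon; in short, a methyl leaves and a hydrogen enters.

Neither measured step touches this spot. For the measured compounds named here, the first step exchanged the group on the far end of the chain, with a 1.5-fold higher number from compound 1 to compound 2 (0.18 log units; within the scatter), within the scatter. The second step replaced the whole chain, giving an at least 2.0-fold higher number from compound 2 to compound 3 (0.31 log units; beyond the scatter). Both steps changed much larger pieces than a single methyl, and the smaller of them stayed within the scatter. A change as small as this one is therefore expected to leave the number close to that of compound 2, with a step of a 1.0-fold lower number from compound 2 to compound 4 (0.00 log units; within the scatter) that is not expected to exceed the scatter. Compound 4 is thus estimated at 24000 nM, with a range from 12000 nM to 50000 nM.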

Compound 4, half-maximal cytotoxic concentration: > 50000 nM
Compound 4: only a limit was reported; the forecaster's own chance of this, stated with the estimate: 20%; middle value at least 2.0-fold (0.31 log units) away from the limit.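

Hydrogen in place of methyl on this saturated chain carbon, bound to an amide-type nitrogen and a carbonyl carbon, gives in this assay an at least 2.0-fold higher number from compound 2 to compound 4 (0.31 log units; beyond the scatter), the only step shown at this place. A single methyl on the chain is therefore enough to change how much compound the cells tolerate by more than the scatter, whereas the much larger exchange at the far end of the chain gave a 1.5-fold higher number from compound 1 to compound 2 (0.18 log units; within the scatter), which stays within the scatter. Compound 4 gives only a limit rather than a number, so its step has a lower bound but no upper one: the limit of > 50000 nM in this assay, at which 1 of the 4 values shown sits.

As far as these compounds go, compound 3 and compound 4 both end in limits, so the step between them cannot be read, and it remains unknown how much compound the cells would tolerate in either case. Also open, from the compounds shown here alone, is whether an ethyl or an isopropyl on this chain carbon would bring the number down further than methyl does, and whether removing the methyl has the same outcome when the far end of the chain carries the group of compound 1 instead of the furan.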